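Changing the group on the ring nitrogen of compound 3

The compounds below may be only part of what the source reports. "The series", "measured", "known", "first", "only" and "open" are said of these compounds alone.

Measured so far in an ADME assay on microsomes from liver (Mus musculus) for metabolic stability, read by LC-MS, using NADPH, with a stated time of 10 min, tested at 0.1 uM; on this read-out lower numbers stand for slow clearance and higher numbers for fast clearance
- compound 1 `C#Cc1cccc(N2C(=O)CSC2c2cccc(C(=O)NCCCCc3ccccc3)c2)c1` gives 1900 mL.min-1.g-1
- compound 2 `O=C(NCCCCc1ccccc1)c1cccc(C2SCC(=O)N2c2cccc(F)c2)c1` gives 2740 mL.min-1.g-1
- compound 3 `O=C(NCCCCc1ccccc1)c1cccc(C2SCC(=O)N2c2ccccc2F)c1` gives 2010 mL.min-1.g-1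

Compound 3 has no clear rank among these values, with a 1.1-fold higher number from compound 1 to compound 3 (0.02 log units; within the scatter) and a 1.4-fold lower number from compound 2 to compound 3 (0.13 log units; within the scatter). The remaining step, a 1.4-fold higher number from compound 1 to compound 2 (0.16 log units; within the scatter), is just as small. Compound 4 `CC(F)(F)c1cccc(N2C(=O)CSC2c2cccc(C(=O)NCCCCc3ccccc3)c2)c1` replaces the 2-fluorophenyl of compound 3, on an amide-type nitrogen in a ring, and the swap amounts to a group of 10 heavy atoms (8 carbon, 2 fluorine; one six-membered aromatic ring of carbon only) in place of a group of 7 heavy atoms (6 carbon, 1 fluorine; one six-membered aromatic ring of carbon only), on an amide-type nitrogen in a ring. Going by the values given here, no measured compound carries the incoming group, so the evidence is indirect. All three measured swaps at this nitrogen stayed within the scatter, so no larger shift is expected here. The expected change is a 1.1-fold higher number from compound 3 to compound 4 (0.04 log units; within the scatter). The estimate for compound 4 is 2200 mL.min-1.g-1, with an expected range from 1200 mL.min-1.g-1 to 3600 mL.min-1.g-1.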

Compound 4, intrinsic clearance in microsomes in the Mus musculus assay: 2010 mL.min-1.g-1
Compound 4: the middle estimate sits 1.1-fold (0.04 log units) above what was measured, within the range that was stated.
By their numbers in the Mus musculus assay, from the lowest: compounds 1, 3, 4 and 2 (each within the scatter of the next).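

In the Mus musculus assay, compound 4 fits with the other compounds, with no change at the digits printed from compound 3 to compound 4 (within the scatter), a 1.4-fold lower number from compound 2 to compound 4 (0.13 log units; within the scatter) and a 1.1-fold higher number from compound 1 to compound 4 (0.02 log units; within the scatter). Going by these compounds alone, the amide-type nitrogen in the ring therefore carries a group of 10 heavy atoms with no step in this read-out beyond the scatter. The same swap does register in a physicochemical assay for solubility, read by turbidimetry, measured as kinetic solubility, at pH 7.4 (a higher number here means a more soluble compound, a lower number a less soluble compound), where compound 3 gives 10000 nM and compound 4 gives 2000 nM, and the larger group goes with a less soluble compound: the measured solubility of compound 3, 10000 nM, and of compound 4, 2000 nM, a 5.0-fold lower number (0.70 log units; beyond the scatter)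

Open, on these data alone, is whether an aromatic ring carrying an amine or a carboxylic acid on this nitrogen would move either read-out.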